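The source may hold more compounds than are shown below. What is called first, only, known or untested is meant among the compounds shown, and "the series" means these compounds.

Values in a functional assay on SK-BR-3 cells (Homo sapiens) for cytotoxicity, read by MTT assay, with a stated time of 72 h; on this read-out lower numbers stand for an effect already at smaller amounts and higher numbers for an effect only at larger amounts of compound:
- compound 1 `O=c1cc(NC2CCCCC2)cc(/C=C/c2ccccc2)o1`: 1.53 uM
- compound 2 `COc1ccc(Nc2cc(C)oc(=O)c2)cc1`: > 30 uM (a limit, not a number)
- compound 3 `COc1ccc(Nc2cc(C3CCCCC3)oc(=O)c2)cc1`: 5.29 uM

Compound 3 at 5.29 uM holds the higher of the two actual numbers, and compound 1 at 1.53 uM lies lower by more than the scatter.

Compound 4 `COc1ccc(Nc2cc(/C=C/c3ccccc3)oc(=O)c2)cc1` is still unmeasured. It differs from compound 3 in one place, with 2-phenylethenyl in place of cyclohexyl on an aromatic carbon, next to the ring oxygen: 2-phenylethenyl in place of cyclohexyl on an aromatic carbon.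

Among the measured compounds shown here, only one measured step touches that carbon: an at least 5.6-fold lower number from compound 2 to compound 3 (0.75 log units; beyond the scatter). It shows that a change there can move the number beyond the scatter, but it says nothing directly about 2-phenylethenyl. Compound 1 does carry 2-phenylethenyl, but it also differs from compound 4 in the other substituent, so it offers indirect support only. The measured value of compound 1 1.53 uM leans the expectation toward a lower number in this assay.

The expected change is a 1.9-fold lower number from compound 3 to compound 4 (0.28 log units; within the scatter), a modest move downward that is not clearly beyond the scatter. For compound 4 the estimated value is 2.8 uM, with an expected range from 0.9 uM to 9 uM.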

Compound 4, concentration for half-maximal effect: 0.083 uM
Compound 4: middle estimate off by 34-fold (1.53 log units), on the high side; measured number below the stated range.
By their numbers in this assay, from the lowest: compound 4; then compound 1; then compound 3. At a limit, above all of these: compound 2.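

In this assay, 2-phenylethenyl in place of cyclohexyl on the aromatic carbon next to the ring oxygen gives a 64-fold lower number from compound 3 to compound 4 (1.80 log units; beyond the scatter), so this carbon distinguishes between two ring-bearing groups and not only between methyl and a ring, which was all that the earlier step of an at least 5.6-fold lower number from compound 2 to compound 3 (0.75 log units; beyond the scatter) could show. Starting from methyl at the same carbon, the change gives an at least 360-fold lower number from compound 2 to compound 4 (2.55 log units; beyond the scatter), and this step starts from a limit, not a number: the limit of > 30 uM in this assay, at which 1 of the 4 values shown sits. Among the compounds shown here, with 2-phenylethenyl held constant, 4-methoxyphenyl in place of cyclohexyl on the nitrogen gives an 18-fold lower number from compound 1 to compound 4 (1.27 log units; beyond the scatter), the first step to isolate that nitrogen substituent, and it lies beyond the scatter as well.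

Which part of 2-phenylethenyl carries the step stays open, since the compounds shown do not separate its double bond from its aromatic ring; a 2-phenylethyl or a plain phenyl group on that carbon would bear on this. Also open, going by these compounds, is how far the number tolerates further groups on that ring, such as an amine or a carboxylic acid, or a replacement of the methoxy group on the 4-methoxyphenyl ring.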